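Adding an Ethyl Group to Compound 3

The source may report more compounds than this note shows. Statements on the series, on what has been measured and on what is new or still open speak of the compounds shown alone.

Compound 3 `COc1cc(C(=O)Nc2nn[nH]n2)nc(-c2ccccc2)c1` gives 62% in a functional assay on the whole organism with Rattus norvegicus as the target, at a dose of 1 mg/kg by the oral route (a lower number here means a weaker effect, a higher number a stronger effect of the compound at the dose given), the second highest of three numbers: compound 2 `Nc1ccc(-c2cc(Cl)cc(C(=O)Nc3nn[nH]n3)n2)cc1` gives 100%, while compound 1 `CCCCc1ccc(-c2cc(Cl)cc(C(=O)Nc3nn[nH]n3)n2)cc1` gives 0%. Compound 4 `CCc1ccc(-c2cc(OC)cc(C(=O)Nc3nn[nH]n3)n2)cc1` differs from compound 3 by ethyl in place of hydrogen on an aromatic carbon. Going by the values given here, the only measured step at that kind of position is a number 100 percentage points higher from compound 1 to compound 2 (beyond the scatter), which compares butyl with amino; neither is ethyl, and no step starts from hydrogen. The expectation leans downward because compound 1, which carries butyl on an aromatic carbon, gives 0%, the lowest number seen, although a change of the core group also separates it from compound 3. Compound 4 is therefore expected to give 35%, within 5% to 70%. That estimate means an expected step of a number 27 percentage points lower from compound 3 to compound 4 (beyond the scatter).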

Compound 4, a percentage reported as inhibition, in the whole organism at one dose (the size of the read-out at that dose, not a potency): 43%
Compound 4: the middle estimate sits 8 percentage points below what was measured; low and high end bracket the measured number.
By their numbers in this assay, from the lowest: compound 1; then compound 4; then compound 3; then compound 2.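

In this assay, going from phenyl to 4-ethylphenyl gives a number 19 percentage points lower from compound 3 to compound 4 (beyond the scatter), the first step shown at this position that starts from hydrogen. Ethyl therefore lowers the read-out on this core without removing it, as compound 4 still gives 43%. No measurement at hand explains the drop. Still open, from the compounds shown here alone, is how a hydroxyl group or a carboxylic acid at this position would compare with ethyl on this core. Butyl and amino also remain to be compared with ethyl on this same core, since they appear here only on the core of compound 1.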